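The source may report more compounds than this note shows. Statements on the series, on what has been measured and on what is new or still open speak of the compounds shown alone.

Of the compounds shown here, three sharing one core have been tested in an ADME assay on HEL cells (Homo sapiens) for cytotoxicity, with a stated time of 3 days; a higher number here means that more compound is tolerated, a lower number that less compound is tolerated. Compound 1 `Cc1cc(-c2ccccc2)cn2c(CSCCc3ccccc3)cnc12` gives 20 ug/mL in this assay. Compound 2 `COc1ccc(-c2cc(C)c3ncc(CSCCc4ccccc4)n3c2)cc1` carries a methoxy in place of hydrogen on an aromatic carbon and gives 20 ug/mL in this assay; the step of no change at the digits printed from compound 1 to compound 2 (within the scatter) stays within the scatter. Compound 3 `Cc1cc(-c2ccc(C#N)cc2)cn2c(CSCCc3ccccc3)cnc12` returns only a limit in this assay, namely >= 20 ug/mL. The steps of a number no lower from compound 1 to compound 3 (the limit leaves the size open) and a number no lower from compound 2 to compound 3 (the limit leaves the size open) therefore have no readable size; they show only that the tolerated amount did not fall, which follows from the limit of >= 20 ug/mL in this assay, at which 1 of the 3 values shown sits. Compound 4 `Cc1cc(-c2ccccc2O)cn2c(CSCCc3ccccc3)cnc12` is not yet measured. Its difference from compound 3 is 2-hydroxyphenyl in place of 4-cyanophenyl on an aromatic carbon. Among the compounds with values here, no measured step introduces a 2-hydroxyphenyl, so the only guide is that exchanging the group on this aromatic carbon, from hydrogen to methoxy or to cyano, has so far left the value at the same level or no lower. The expected step of a number no higher from compound 3 to compound 4 (the limit leaves the size open) is therefore none beyond the scatter. Compound 4 is estimated at 20 ug/mL, between 10 ug/mL and 40 ug/mL in this assay.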

Compound 4, minimum cytotoxic concentration: 100 ug/mL
Compound 4: middle estimate off by 5.0-fold (0.70 log units), on the low side; measured number above the stated range.
By their numbers in this assay, from the lowest: compounds 1 and 2 (each within the scatter of the next); then compound 4.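

In this assay, hydroxy in place of hydrogen on the phenyl ring gives a 5.0-fold higher number from compound 1 to compound 4 (0.70 log units; beyond the scatter), and 2-hydroxyphenyl in place of 4-methoxyphenyl gives a 5.0-fold higher number from compound 2 to compound 4 (0.70 log units; beyond the scatter). Within the data shown here, these steps lie beyond the scatter, whereas the one earlier readable step, methoxy in place of hydrogen, did not, so the group on this aromatic carbon can shift the tolerated amount. No size can be given for the step involving compound 3, which gives only a limit: the limit of >= 20 ug/mL in this assay, at which 1 of the 4 values shown sits.

Whether this rise depends on the hydroxy itself or on its place on the phenyl ring stays open, since the compounds shown include no phenyl ring bearing an amine or a carboxylic acid and none with the hydroxy elsewhere on the ring. On these data alone, how far above its limit compound 3 lies also remains unknown.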